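The source may report more compounds than this note shows. Statements on the series, on what has been measured and on what is new or still open speak of the compounds shown alone.

For the measured compounds named here, in a functional assay on ACHN cells (Homo sapiens) for inhibition, read by sulforhodamine B assay, with a stated time of 48 h, tested at 10 uM (on this read-out lower numbers stand for less inhibition and higher numbers for more inhibition at the one concentration tested (going by the name of the read-out)), compound 3 `Fc1ccccc1-c1cn2ccnc2c(-c2ccc3ncn(C4CCCCC4)c3c2)n1` gives 13.2%, the second highest of the three numbers known so far. Its nearest neighbour is compound 2 `COc1ccccc1-c1cn2ccnc2c(-c2ccc3ncn(C4CCCCC4)c3c2)n1`, which in this assay gives 4.48%; the step of a number 8.7 percentage points higher from compound 2 to compound 3 (within the scatter) lies within the scatter. Furthest off is compound 1 `COc1ccc(-c2cn3ccnc3c(-c3ccc4ncn(C5CCCCC5)c4c3)n2)cc1`, which in this assay gives 61%; the step of a number 47.8 percentage points lower from compound 1 to compound 3 (beyond the scatter) is beyond the scatter, as is a number 56.5 percentage points lower from compound 1 to compound 2 (beyond the scatter).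

Compound 4 `FC(F)(F)c1cccc(-c2cn3ccnc3c(-c3ccc4ncn(C5CCCCC5)c4c3)n2)c1` carries 3-(trifluoromethyl)phenyl in place of 2-fluorophenyl on an aromatic carbon. Going by the values given here, no measured step bears directly on a 3-(trifluoromethyl)phenyl group. The two large steps, a number 47.8 percentage points lower from compound 1 to compound 3 (beyond the scatter) and a number 56.5 percentage points lower from compound 1 to compound 2 (beyond the scatter), both replace 4-methoxyphenyl, while the small step of a number 8.7 percentage points higher from compound 2 to compound 3 (within the scatter) swaps fluoro for methoxy and stays within the scatter. Whether compound 4 will sit near compound 3 or move back toward compound 1 cannot be read from these three alone. The expectation for compound 4 is therefore only a modest rise, a number 6.8 percentage points higher from compound 3 to compound 4 (within the scatter), carrying wide uncertainty. Compound 4 is estimated at 20%, with a range from 3% to 50%.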

Compound 4, a percentage reported as inhibition, at one concentration (the size of the read-out at that concentration, not a potency): 0.3%
Compound 4: the middle estimate sits 19.7 percentage points above what was measured; the measured number lies below the stated range.
By their numbers in this assay, from the lowest: compounds 4, 2 and 3 (each within the scatter of the next, the first and the last beyond it); then compound 1.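

In this assay, the 3-(trifluoromethyl)phenyl group does not bring this position back toward the 4-methoxyphenyl group, with a number 60.7 percentage points lower from compound 1 to compound 4 (beyond the scatter) and a size as large as the two earlier steps away from compound 1. Low numbers are thus no longer held only by the 2-methoxyphenyl and 2-fluorophenyl groups, although the new group separates unevenly from these two: a number 4.2 percentage points lower from compound 2 to compound 4 (within the scatter) but a number 12.9 percentage points lower from compound 3 to compound 4 (beyond the scatter) in the same read-out. Nothing measured here accounts for the low number of compound 4.

The compounds shown leave open whether the number of compound 1 depends on the methoxy group itself or on where it sits on the phenyl ring. They also leave open how a 4-fluorophenyl, 4-aminophenyl or 4-carboxyphenyl group would read at this position.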